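Moving the nitrile around the pyridine of compound 3

A few compounds are considered here, and "the series" means these few. Any claim that something is new, unique, unknown or untested is made for them only; others in the source may bear on it.

Compound 1 `O=C([C@@H]1C[C@H](N2CCN(c3ccc(Br)cc3)CC2)CN1)N1CCSC1`: 9 nM
Compound 2 `O=C([C@@H]1C[C@H](N2CCN(c3ccc(Cl)c(Cl)c3)CC2)CN1)N1CCSC1`: 4.2 nM
Compound 3 `N#Cc1ccnc(N2CCN([C@@H]3CN[C@H](C(=O)N4CCSC4)C3)CC2)c1`: 1.9 nM

In an assay on a cell-free system (plasma) for inhibition of Dipeptidyl peptidase 4 (Rattus norvegicus), read by fluorescence (on this read-out lower numbers stand for stronger inhibition and higher numbers for weaker inhibition), compound 3 gives the lowest number of the three, with compound 2 nearest at a 2.2-fold lower number from compound 2 to compound 3 (0.34 log units; beyond the scatter) and compound 1 furthest at a 4.7-fold lower number from compound 1 to compound 3 (0.68 log units; beyond the scatter). Compound 4 `N#Cc1cccnc1N1CCN([C@@H]2CN[C@H](C(=O)N3CCSC3)C2)CC1` keeps the same atoms, joined differently: 3-cyanopyridin-2-yl in place of 4-cyanopyridin-2-yl on an amine nitrogen in a ring. For the measured compounds named here, no measured step swaps one cyanopyridinyl for another; the aryl swaps seen, a 2.1-fold lower number from compound 1 to compound 2 (0.33 log units; beyond the scatter), a 4.7-fold lower number from compound 1 to compound 3 (0.68 log units; beyond the scatter) and a 2.2-fold lower number from compound 2 to compound 3 (0.34 log units; beyond the scatter), were all modest, so a change within the scatter or a small step either way is expected in this assay. Compound 4 is expected to give 2.5 nM, with a range from 0.8 nM to 8 nM, which means an expected step of a 1.3-fold higher number from compound 3 to compound 4 (0.12 log units; within the scatter).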

Compound 4, half-maximal inhibitory concentration: 1.2 nM
Compound 4: middle estimate off by 2.1-fold (0.32 log units), on the high side; the measured number falls inside the stated range.
By their numbers in this assay, from the lowest: compounds 4 and 3 (each within the scatter of the next); then compound 2; then compound 1.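

Moving the nitrile from 4-cyanopyridin-2-yl to 3-cyanopyridin-2-yl gives, in this assay, a 1.6-fold lower number from compound 3 to compound 4 (0.20 log units; within the scatter), so the two placements are not told apart by this read-out. The 3-cyanopyridin-2-yl group also stands clear of the halogenated aryl groups, with a 3.5-fold lower number from compound 2 to compound 4 (0.54 log units; beyond the scatter) and a 7.5-fold lower number from compound 1 to compound 4 (0.88 log units; beyond the scatter). No evidence is available to explain why the two placements read alike. Still open, on these data alone, is how 5-cyanopyridin-2-yl would read, and whether the nitrile itself matters, as a carboxylic acid or an amine in its place would show.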